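Replacing methoxy with dimethylamino in compound 3

The source may report more compounds than this note shows. Statements on the series, on what has been measured and on what is new or still open speak of the compounds shown alone.

In a functional assay on DWD cells (Homo sapiens) for inhibition, read by sulforhodamine B assay (on this read-out higher numbers stand for weaker inhibition of growth and lower numbers for stronger inhibition of growth), compound 3 (`COc1ccc(-c2ccc(-c3ccc(-c4nc5ccccc5[nH]4)cc3)cc2)cc1`) gives 100000 nM and stands level with compound 2 (`FC(F)(F)Oc1ccc(-c2ccc(-c3ccc(-c4nc5ccccc5[nH]4)cc3)cc2)cc1`) at 100000 nM as the highest number of the three. Much lower than both, compound 1 (`Cc1ccc2[nH]c(-c3ccc(-c4ccc(-c5ccc(N(C)C)cc5)cc4)cc3)nc2c1`) gives 3230 nM and carries dimethylamino. Compound 4 (`CN(C)c1ccc(-c2ccc(-c3ccc(-c4nc5ccccc5[nH]4)cc3)cc2)cc1`) has dimethylamino in place of methoxy on an aromatic carbon. Among the measured compounds shown here, the one measured step shows no change at the digits printed from compound 2 to compound 3 (within the scatter) when methyl replaces trifluoromethyl on an oxygen on an aromatic ring. That step does not test dimethylamino, so the guide is compound 1 at 3230 nM even though the core of compound 1 is not the same. A large fall is therefore expected, with a 17-fold lower number from compound 3 to compound 4 (1.22 log units; beyond the scatter) as the estimated step. In this assay the estimate for compound 4 is 6000 nM and 1500 nM to 40000 nM is the expected range.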

Compound 4, concentration for 50% growth inhibition: 100000 nM
Beside the measured number, compound 4's estimate is 17-fold (1.22 log units) below it; measured number outside the range, above it.
By their numbers in this assay, from the lowest: compound 1; then compounds 2, 3 and 4 (each within the scatter of the next).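

In this assay, dimethylamino in place of methoxy on this aromatic carbon gives no change at the digits printed from compound 3 to compound 4 (within the scatter), and dimethylamino in place of trifluoromethoxy gives no change at the digits printed from compound 2 to compound 4 (within the scatter), so the three groups read alike on the shared core. Hydrogen in place of methyl on an aromatic carbon gives a 31-fold higher number from compound 1 to compound 4 (1.49 log units; beyond the scatter), so dimethylamino alone does not carry the low number of compound 1; in that pair, the methyl is the one difference. Nothing shown here explains this. Going by these compounds, it stays open whether methoxy would also give a low number alongside that methyl, and whether a carboxylic acid or a piperazine on this aromatic carbon would read differently.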